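Amide-bearing thiazolidinone series: aryl swap on the ring nitrogen

The source may hold more compounds than are shown below. What is called first, only, known or untested is meant among the compounds shown, and "the series" means these compounds.

Measured so far:
compound 1 `COc1ccccc1N1C(=O)C(C)SC1c1cccc(C(=O)NCCCCc2ccccc2)c1` — 38%
compound 2 `COc1ccccc1N1C(=O)CSC1c1cc(F)cc(C(=O)O)c1` — 15%
compound 3 `COc1cccc(OC)c1N1C(=O)CSC1c1cccc(C(=O)NCCCCc2ccccc2)c1` — 41%

All three were run in a functional assay on U2OS cells (Homo sapiens) for inhibition, read by CCK-8 assay, with a stated time of 72 h, tested at 1 uM; a higher number here means more inhibition at the concentration tested (going by the name of the read-out), a lower number less inhibition. Compound 3 gives the highest of the three numbers, but compound 1 lies only a few points lower, within the usual scatter, so the two cannot be ordered. Compound 2, which carries a carboxylic acid in place of the amide and a fluorine on the pendant ring, sits well below both, and that gap to compound 3 is beyond the scatter. No single-point comparison between measured compounds is available, so the acid-for-amide change and the aryl changes cannot be separated on these data.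

Compound 4 `CC(F)(F)c1cccc(N2C(=O)CSC2c2cccc(C(=O)NCCCCc3ccccc3)c2)c1` keeps the amide of compound 3 and differs only at the aryl group on the ring nitrogen: a group of 10 heavy atoms (8 carbon, 2 fluorine; one six-membered aromatic ring of carbon only) in place of a group of 10 heavy atoms (8 carbon, 2 oxygen; one six-membered aromatic ring of carbon only), on an amide-type nitrogen in a ring. Nothing measured speaks to this exchange directly. Given that compound 1 and compound 3, which differ at the same aryl position, sit within the scatter of each other, a step from compound 3 to compound 4 of a number 6 percentage points lower from compound 3 to compound 4 (within the scatter) is expected, modest and downward, not clearly beyond the scatter. Compound 4 is estimated at 35%, with a plausible range of 15% to 55%.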

Compound 4, a percentage reported as inhibition, at one concentration (the size of the read-out at that concentration, not a potency): 24%
For compound 4 the middle estimate is 11 percentage points above the measured one; measured number inside the range.
By their numbers in this assay, from the lowest: compounds 2 and 4 (each within the scatter of the next); then compounds 1 and 3 (each within the scatter of the next).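

At the amide-type nitrogen in the ring, exchanging 2,6-dimethoxyphenyl for the aryl group with 8 carbon and 2 fluorine atoms gives, in this assay, a number 17 percentage points lower from compound 3 to compound 4 (beyond the scatter). Within the data shown here, this is the first comparison that isolates a single place, and it shows that the read-out at this concentration depends on which aryl group sits here, something the earlier compounds, which differ in more than one place, could not show. The two groups have the same count of heavy atoms and the same single six-membered aromatic ring, and differ in trading 2 hydrogen-bond acceptors for none and oxygen for fluorine, but no measurement here ties the step to any of these differences.

Still open, going by these compounds, is whether the loss of the two methoxy groups or the arrival of the fluorinated group accounts for the step, a question that an unsubstituted phenyl or a phenyl with one methoxy group at this nitrogen would help to separate. Also open, on these data alone, is how far the step carries over to the carboxylic acid series, and whether it would hold across a range of concentrations rather than at one.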